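The compounds below may be only part of what the source reports. "The series", "measured", "known", "first", "only" and "open" are said of these compounds alone.

Compound 1 `CC(C)c1ccc(-c2nc(SCc3cn(CC(=O)NC(=O)Nc4ccccn4)nn3)nc(Nc3cccc(C(F)(F)F)c3)c2C#N)cc1` is the starting point. In a functional assay on ECa-109 cells (Homo sapiens) for inhibition, read by MTT assay, with a stated time of 72 h (on this read-out lower numbers stand for stronger inhibition and higher numbers for weaker inhibition), compound 1 gives 24200 nM. Compound 2 `CC(C)c1ccc(Nc2nc(SCc3cn(CC(=O)NC(=O)Nc4ccccn4)nn3)nc(-c3ccc(C(C)C)cc3)c2C#N)cc1` differs from it by 4-isopropylphenyl in place of 3-(trifluoromethyl)phenyl on a nitrogen on an aromatic ring, and in this assay compound 2 gives 2490 nM, so that a 9.7-fold lower number from compound 1 to compound 2 (0.99 log units; beyond the scatter). Compound 3 `N#Cc1c(Nc2cccc(C(F)(F)F)c2)nc(SCc2cn(CC(=O)NC(=O)Nc3ccccn3)nn2)nc1-c1ccc(Br)cc1` differs from compound 1 in another way, by bromo in place of isopropyl on an aromatic carbon; in this assay compound 3 gives 2960 nM, which means an 8.2-fold lower number from compound 1 to compound 3 (0.91 log units; beyond the scatter). The values of compound 2 and compound 3 lie within the usual scatter of each other.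

Compound 4 `CC(C)c1ccc(Nc2nc(SCc3cn(CC(=O)NC(=O)Nc4ccccn4)nn3)nc(-c3ccc(Br)cc3)c2C#N)cc1` has not yet been measured. It differs from compound 3 by 4-isopropylphenyl in place of 3-(trifluoromethyl)phenyl on a nitrogen on an aromatic ring, the same change that separates compound 2 from compound 1, made this time on the core of compound 3, which differs from the core of compound 1 by bromo in place of isopropyl on an aromatic carbon. The place of the change is described in the same words in both cases, so it is the same change on a different core.

Beside the earlier step, the step expected from compound 3 to compound 4 is a 4.9-fold lower number from compound 3 to compound 4 (0.69 log units; beyond the scatter). This rests on compound 1, because a 9.7-fold lower number from compound 1 to compound 2 (0.99 log units; beyond the scatter); a second case on another core may not repeat it fully. Compound 4 is estimated to give 600 nM in this assay, with the likely range running from 200 nM to 2000 nM.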

Compound 4, half-maximal inhibitory concentration: > 64000 nM
Compound 4: a limit, no number (the forecaster's own chance of this, stated with the estimate: 2%); middle value at least 100-fold (2.02 log units) from the limit.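

In this assay compound 4 gives > 64000 nM, which is a limit of the assay and not a number. On the core of compound 3, putting 4-isopropylphenyl in place of 3-(trifluoromethyl)phenyl gives an at least 21-fold higher number from compound 3 to compound 4 (1.33 log units; beyond the scatter), the opposite direction to the same change on the core of compound 1, so this change does not carry from one core to the other: the same change on two cores in this assay, a 9.7-fold lower number (0.99 log units; beyond the scatter) from compound 1 to compound 2 and an at least 21-fold higher number (1.33 log units; beyond the scatter) from compound 3 to compound 4, at least 210-fold (2.32 log units) apart, beyond the scatter of two such steps

Bromo in place of isopropyl gives an at least 25-fold higher number from compound 2 to compound 4 (1.40 log units; beyond the scatter), which also reverses its earlier step, showing that each change depends on what sits at the other place, though not why, nor how large the true gap is, since one end of it is a limit: the same change on two cores in this assay, an 8.2-fold lower number (0.91 log units; beyond the scatter) from compound 1 to compound 3 and an at least 25-fold higher number (1.40 log units; beyond the scatter) from compound 2 to compound 4, at least 210-fold (2.32 log units) apart, beyond the scatter of two such steps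

The compounds shown leave open whether this reversal is special to the bromo and isopropyl pair, or whether a chloro or methoxy group in place of bromo would behave the same way. As far as these compounds go, it is also open how a simple unsubstituted phenyl on the nitrogen would fit into this picture.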